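Swapping the Acetyl Cap on the Piperidine Nitrogen

The compounds below may be only part of what the source reports. "The series", "measured", "known", "first", "only" and "open" are said of these compounds alone.

Measured so far:
compound 1, `CC(=O)N1CCC(c2cc3c(-c4ccc(=O)n(C(C)C)c4)ccnc3[nH]2)CC1` — < 3 uL/min
compound 2, `CN(C)C(=O)CN1CCC(c2cc3c(-c4ccc(=O)n(C5CCOCC5)c4)ccnc3[nH]2)CC1` — 8.2 uL/min

In an ADME assay on microsomes from liver (Homo sapiens) for metabolic stability (a lower number here means slower removal, a higher number faster removal of the compound), compound 1 gives < 3 uL/min, which is a limit of the assay and not a number. Compound 2 is measured at 8.2 uL/min in this assay. Within the data shown here, the two compounds differ in more than one place, so the pair carries no single step; their values only show that one sits at the limit and the other above it, per (the limit of < 3 uL/min in this assay, at which 1 of the 2 values shown sits).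

Compound 3, `CC(C)n1cc(-c2ccnc3[nH]c(C4CCN(CC(=O)N(C)C)CC4)cc23)ccc1=O`, is the untested partner of compound 1. The change is (dimethylcarbamoyl)methyl in place of acetyl on an amine nitrogen in a ring. Among the measured compounds shown here, no measured step matches this exchange alone. Compound 2, which carries the same (dimethylcarbamoyl)methyl group, gives a readable number, so the step from compound 1 to compound 3 is expected to be a modest rise in this assay, an at least 1.6-fold higher number from compound 1 to compound 3 (0.22 log units; that floor lies within the scatter), possibly within the scatter. Compound 3 is estimated at 5 uL/min, between 2 uL/min and 12 uL/min.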

Compound 3, intrinsic clearance in a liver preparation (reported as CLH), per the amount of preparation that the assay uses: < 3 uL/min
Compound 3: a limit, no number; the forecaster's own chance of this, stated with the estimate: 30%; at least 1.6-fold (0.22 log units) between middle value and limit.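

In this assay compound 3 gives < 3 uL/min which is a limit of the assay and not a number. With isopropyl on the aromatic nitrogen, the (dimethylcarbamoyl)methyl group on the amine nitrogen in the ring therefore gives no readable value, and the acetyl group gives none either: the limit of < 3 uL/min in this assay, at which 2 of the 3 values shown sit. Isopropyl in place of oxan-4-yl on an aromatic nitrogen gives an at least 2.7-fold lower number from compound 2 to compound 3 (0.43 log units; beyond the scatter) and is the only new step that can be read, while the step between the two limits cannot.

Going by these compounds, how far apart acetyl and (dimethylcarbamoyl)methyl truly lie on the amine nitrogen in the ring stays open, as does the value of the acetyl group alongside oxan-4-yl. Also open, on these data alone, is where a cyclopropyl group or a longer chain on the aromatic nitrogen would fall in this assay and whether it would leave the limit.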